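Swapping a side group on compound 2

A few compounds are considered here, and "the series" means these few. Any claim that something is new, unique, unknown or untested is made for them only; others in the source may bear on it.

In a functional assay on SMMC-7721 cells (Homo sapiens) for antiproliferative activity, read by MTT assay, with a stated time of 48 h (a lower number here means a stronger inhibitor, a higher number a weaker inhibitor), compound 1 `CCN(CC)C/C1=C/C[C@](C)(CCC=C(C)C)/C=C/[C@@H](OC(=O)C=C(C)C)[C@](C)(O)/C=C/C1=O` gives 570 nM and compound 2 `CC(C)=CCC[C@]1(C)/C=C/[C@@H](OC(=O)C=C(C)C)[C@](C)(O)/C=C/C(=O)/C(CN2CCN(C)CC2)=C\C1` gives 2940 nM, so compound 2 has the higher number of the two and is the weaker inhibitor. Compound 3 `CC(C)=CCC[C@]1(C)/C=C/[C@@H](OC(=O)C=C(C)C)[C@](C)(O)/C=C/C(=O)/C(C(=O)N(C)C)=C\C1` keeps the shared core but carries dimethylcarbamoyl in place of (4-methylpiperazin-1-yl)methyl on a double-bonded ring carbon. Among the compounds with values here, only one measured step bears on this change: a 5.2-fold higher number from compound 1 to compound 2 (0.71 log units; beyond the scatter). It suggests that the group at this place can move the number by a modest amount. Within the data shown here, that step only exchanged one group on the saturated chain carbon for another, however, and no measured compound lacks that carbon. Its size and direction therefore guide the new step only loosely, and no clear step beyond the scatter is expected. The estimated step is a 1.2-fold higher number from compound 2 to compound 3 (0.08 log units; within the scatter). The expected value for compound 3 is 3500 nM, within a range from 1000 nM to 12000 nM.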

Compound 3, half-maximal inhibitory concentration: 3670 nM
Estimate against measurement, compound 3: 1.0-fold (0.02 log units) below; the range from low to high includes it.
By their numbers in this assay, from the lowest: compound 1; then compounds 2 and 3 (each within the scatter of the next).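

In this assay the change from (4-methylpiperazin-1-yl)methyl to dimethylcarbamoyl gives a 1.2-fold higher number from compound 2 to compound 3 (0.10 log units; within the scatter) and so shows that this double-bonded ring carbon can carry these two quite different groups, one with a ring and one with a carbonyl and no ring, without a clear shift in the number. The same dimethylcarbamoyl group gives a 6.4-fold higher number from compound 1 to compound 3 (0.81 log units; beyond the scatter) and so shows that, among these three groups, only the (diethylamino)methyl group of compound 1 stands apart, beyond the scatter from both others. No measurement shown here explains this difference.

Still open, from the compounds shown here alone, is whether a (dimethylamino)methyl or (pyrrolidin-1-yl)methyl group would read like compound 1 or like compound 2. Going by these compounds, how a carboxylic acid or a longer amine chain on this carbon would read also remains unknown.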